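A few compounds are considered here, and "the series" means these few. Any claim that something is new, unique, unknown or untested is made for them only; others in the source may bear on it.

Compound 2 `CS(=O)(=O)c1cnc(O[C@H]2CC[C@H](OC3CCN(C(=O)OC4CCOC4)CC3)CC2)cn1` gives, in a functional assay on isolated protein for agonist activity at Glucose-dependent insulinotropic receptor (Homo sapiens), read by HTRF and cAMP accumulation (a lower number here means that less compound is needed, a higher number that more compound is needed for the effect), a value of 427 nM, the higher of the two numbers seen so far. Compound 1 `C[C@@H](CF)OC(=O)N1CCC(O[C@H]2CC[C@H](Oc3cnc(S(C)(=O)=O)cn3)CC2)CC1` gives 31.1 nM in this assay, and the step of a 14-fold higher number from compound 1 to compound 2 (1.14 log units; beyond the scatter) is large. Going by the values given here, compound 3 `CS(=O)(=O)c1cnc(O[C@H]2CC[C@H](OC3CCN(CC4(C(F)(F)F)CCC4)CC3)CC2)cn1` carries a different change, ((1-(trifluoromethyl)cyclobutyl)methyl in place of ((oxolan-3-yl)oxy)carbonyl on an amine nitrogen in a ring), and no measured step touches that ring nitrogen, so the single step from compound 1 to compound 2 is only a loose guide. For compound 3 the expected value is 300 nM, within 60 nM to 1500 nM. The expected step is a 1.4-fold lower number from compound 2 to compound 3 (0.15 log units; within the scatter).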

Compound 3, half-maximal effective concentration: 54.8 nM
Compound 3: the middle estimate sits 5.5-fold (0.74 log units) above what was measured, and the stated range ends above it.
By their numbers in this assay, from the lowest: compounds 1 and 3 (each within the scatter of the next); then compound 2.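

In this assay a carbonyl on the amine nitrogen in a ring proves unnecessary for a low number: (1-(trifluoromethyl)cyclobutyl)methyl in place of ((oxolan-3-yl)oxy)carbonyl gives a 7.8-fold lower number from compound 2 to compound 3 (0.89 log units; beyond the scatter) and has no hydrogen-bond acceptors. Going by these compounds alone, the same group set against the one in compound 1 gives a 1.8-fold higher number from compound 1 to compound 3 (0.25 log units; within the scatter) so these two quite different groups cannot be told apart here. No measurement shown explains either step. As far as these compounds go, whether the trifluoromethyl or the four-membered ring matters more stays open, as does how a plain cyclobutylmethyl or a simple butyl chain on this nitrogen would behave.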